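This account rests on a few compounds, and the source may have more. Where it says the series, first, only, none or still open, it means among the compounds named here.

Of the compounds shown here, two have been measured in a functional assay on HEK293 cells for agonist activity at D(4) dopamine receptor (Homo sapiens), read by FLIPR; on this read-out lower numbers stand for an effect already at smaller amounts and higher numbers for an effect only at larger amounts of compound. Compound 1 `Cc1cc(NC(=O)CN2CCC(c3cccc[n+]3[O-])CC2)ccc1F` gives 18 nM, which is the higher of the two numbers. Compound 2 `Oc1ccc(N2CCN(Cc3nc4ccccc4[nH]3)CC2)nc1`, built differently, gives 2.4 nM in this assay. Compound 3 `Cc1cc(Br)ccc1NC(=O)CN1CCC(c2cccc[n+]2[O-])CC1` comes from compound 1 through a single change: 4-bromo-2-methylphenyl in place of 4-fluoro-3-methylphenyl on an amide-type nitrogen. Within the data shown here, no measured pair shows this change, so nothing in the data fixes its size or direction. The step expected here is a 1.7-fold higher number from compound 1 to compound 3 (0.22 log units; within the scatter), a small shift toward a higher number that may well stay within the scatter. Compound 3 is therefore estimated at 30 nM, with a range from 8 nM to 120 nM.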

Compound 3, half-maximal effective concentration: 66 nM
The estimate for compound 3 lay 2.2-fold (0.34 log units) below the measured number, within the range that was stated.
By their numbers in this assay, from the lowest: compound 2; then compound 1; then compound 3.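

The group on the amide-type nitrogen is not a silent place in this assay: putting 4-bromo-2-methylphenyl in place of 4-fluoro-3-methylphenyl gives a 3.7-fold higher number from compound 1 to compound 3 (0.56 log units; beyond the scatter). The two groups match in heavy atoms, hydrogen-bond donors and acceptors, so these counts do not separate them. Nothing measured here accounts for the step.

From the compounds shown here alone, the halogen and the place of the methyl differ together, so the share of each remains open. Also open, going by these compounds, is how a phenyl group carrying an amine or a carboxylic acid would read here.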